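Swapping the amide ring on a shared stilbene core

The source may hold more compounds than are shown below. What is called first, only, known or untested is meant among the compounds shown, and "the series" means these compounds.

Of the compounds shown here, three that share one core have been measured in a functional assay on B16-F10 cells (Mus musculus) for inhibition, read by MTT assay, with a stated time of 48 h; on this read-out higher numbers stand for weaker inhibition and lower numbers for stronger inhibition. Compound 1 `COc1ccc(/C=C/c2cc(OC)cc(OC)c2/C=C/C(=O)Nc2cc(OC)c(OC)c(OC)c2)cc1` gives 8150 nM in this assay. Compound 2 `COc1ccc(/C=C/c2cc(OC)cc(OC)c2/C=C/C(=O)NC2CC2)cc1`, which carries a cyclopropyl in place of the 3,4,5-trimethoxyphenyl on the amide-type nitrogen, gives 10200 nM. Compound 3 `COc1ccc(/C=C/c2cc(OC)cc(OC)c2/C=C/C(=O)N2CCCCC2C)cc1`, with a 2-methylpiperidin-1-yl in place of the cyclopropylamino on the carbonyl carbon, gives 7660 nM. Compound 3 thus carries the lowest of the three numbers, but its distance to compound 1 and to compound 2 stays within the scatter, so no ordering among the three can be claimed.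

Compound 4 `COc1ccc(/C=C/c2cc(OC)cc(OC)c2/C=C/C(=O)N2CCCC2)cc1` has not yet been measured. It differs from compound 3 in one place: pyrrolidin-1-yl in place of 2-methylpiperidin-1-yl on a carbonyl carbon.

Both measured steps alter the group attached to the amide carbonyl, so both bear on this change. The step of a 1.3-fold higher number from compound 1 to compound 2 (0.10 log units; within the scatter) and the step of a 1.3-fold lower number from compound 2 to compound 3 (0.12 log units; within the scatter) were each small. Those exchanges, one of them also trading one ring-bearing group for another on the carbonyl carbon, left the read-out unchanged beyond the scatter. The expected step is therefore a 1.0-fold higher number from compound 3 to compound 4 (0.02 log units; within the scatter), meaning no change beyond the scatter. Compound 4 is expected to give 8000 nM, with a range from 4000 nM to 16000 nM.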

Compound 4, half-maximal inhibitory concentration: 9280 nM
For compound 4 the middle estimate is 1.2-fold (0.06 log units) below the measured one; the range from low to high includes it.
By their numbers in this assay, from the lowest: compounds 3, 1, 4 and 2 (each within the scatter of the next).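

Replacing the 2-methylpiperidin-1-yl on the carbonyl carbon with pyrrolidin-1-yl removes the methyl and narrows the ring from six-membered to five-membered, yet in this assay the read-out stays within the scatter (a 1.2-fold higher number from compound 3 to compound 4 (0.08 log units; within the scatter)). Compound 4 also stays within the scatter of the open-chain-free secondary amide of compound 2 (a 1.1-fold lower number from compound 2 to compound 4 (0.04 log units; within the scatter)), so a five-membered ring, a six-membered ring with a methyl and a cyclopropylamino group on this carbonyl carbon cannot be told apart here. No information is available on why these exchanges leave the number in place.

All the groups shown at this position consist of carbon and nitrogen in the part that changes, apart from the methoxy groups of the 3,4,5-trimethoxyphenyl on compound 1, and none carries a net charge where this is printed. On these data alone, it remains open whether morpholin-4-yl, piperazin-1-yl or a longer chain ending in a carboxylic acid or an amine would move the read-out beyond the scatter, or whether this position simply tolerates whatever is placed on it.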